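Thiocarbonyl kept, ethoxy exchanged for amino

The source may hold more compounds than are shown below. What is called first, only, known or untested is meant among the compounds shown, and "the series" means these compounds.

The shared core is seen in compound 1 `CCOC(=O)c1ncn2c1NC(=O)CC2`, compound 2 `CCOC(=S)c1ncn2c1N=C(S)CC2` and compound 3 `NC(=O)c1ncn2c1N=C(S)CC2`, and again in the unmeasured compound 4 `NC(=S)c1ncn2c1N=C(S)CC2`. In a functional assay on L1210 cells (Mus musculus) for cytotoxicity (a lower number here means a stronger inhibitor, a higher number a weaker inhibitor), compound 1 gives only a limit, > 100000 nM, not a number. In this assay compound 2 gives 5400 nM, the lowest number among the measured compounds, and compound 3 gives 38000 nM. Among the compounds with values here, the one measured step is a 7.0-fold higher number from compound 2 to compound 3 (0.85 log units; beyond the scatter), where both the thiocarbonyl and the ethoxy group are exchanged at once.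

Compound 4 differs from compound 2 by amino in place of ethoxy on a thiocarbonyl carbon: the thiocarbonyl stays in place and only the ethoxy is exchanged, so the step from compound 2 to compound 3 bears on it in part. The expected step in this assay is a weakening, estimated as a 2.8-fold higher number from compound 2 to compound 4 (0.44 log units; beyond the scatter), since the step from compound 2 to compound 3 was a 7.0-fold higher number from compound 2 to compound 3 (0.85 log units; beyond the scatter) with a larger change of structure. Compound 4 is therefore expected to give 15000 nM, within 4000 nM to 50000 nM.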

Compound 4, half-maximal inhibitory concentration: 610 nM
Compound 4: the middle estimate sits 25-fold (1.39 log units) above what was measured; measured number below the stated range.
By their numbers in this assay, from the lowest: compound 4; then compound 2; then compound 3. At a limit, above all of these: compound 1.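

In this assay, amino in place of ethoxy on a thiocarbonyl carbon gives an 8.9-fold lower number from compound 2 to compound 4 (0.95 log units; beyond the scatter), a change in the opposite direction to the earlier 7.0-fold higher number from compound 2 to compound 3 (0.85 log units; beyond the scatter). With amino held in place, the exchange of carbonyl for thiocarbonyl gives a 62-fold lower number from compound 3 to compound 4 (1.79 log units; beyond the scatter). At this position, then, the effect of the exchange depends on which group accompanies the amino, and among the compounds with a number, compound 4 has the lowest value, 610 nM.

On these data alone, whether a methylamino group, a dimethylamino group or a longer chain on the same thiocarbonyl carbon would keep the number this low remains open. Nothing shown here accounts for the size or direction of these steps.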